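A few compounds are considered here, and "the series" means these few. Any claim that something is new, unique, unknown or untested is made for them only; others in the source may bear on it.

In an ADME assay on MT4 cells (Homo sapiens) for cytotoxicity, read by MTT assay, with a stated time of 4 days (a higher number here means that more compound is tolerated, a lower number that less compound is tolerated), compound 1 `O=c1cc(Cc2c(F)cccc2F)nc(N2CCC3(CC2)OCCO3)[nH]1` gives > 69000 nM, which is a limit of the assay. Compound 2 `Cc1c(Cc2c(F)cccc2F)nc(N(C)C(C)C)[nH]c1=O` gives a measured number, 79000 nM. Compound 3 `Cc1c(C(C)c2c(F)cccc2F)nc(N(C)C(C)C)[nH]c1=O` gives > 81000 nM, which is also a limit and not a number. Compound 4 `Cc1c(C(C)c2c(F)cccc2F)nc(N2CCCCCC2)[nH]c1=O` carries azepan-1-yl in place of isopropyl(methyl)amino on an aromatic carbon, between two ring nitrogen atoms: azepan-1-yl in place of isopropyl(methyl)amino on an aromatic carbon. Among the measured compounds shown here, the only measured step, an at least 1.0-fold higher number from compound 2 to compound 3 (0.01 log units; that floor lies within the scatter), comes from methyl in place of hydrogen elsewhere in the molecule, so it bears only indirectly on this change. For the measured compounds named here, with that step as the sole guide, an at least 1.2-fold lower number from compound 3 to compound 4 (0.09 log units; that floor lies within the scatter) is expected in this assay, with no change expected beyond the scatter. Compound 4 is estimated at 65000 nM, with an expected range from 25000 nM to 130000 nM.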

Compound 4, half-maximal cytotoxic concentration: > 72000 nM
Compound 4: no number, only a limit; the forecaster's own chance of this, stated with the estimate: 40%; middle value at least 1.1-fold (0.04 log units) away from the limit.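

Among the compounds shown here, compound 3 and compound 4 each give only a limit and not a number, so no step between them can be read. As far as these compounds go, what replacing isopropyl(methyl)amino with azepan-1-yl does in this assay stays open.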